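The source may report more compounds than this note shows. Statements on the series, on what has been measured and on what is new or still open speak of the compounds shown alone.

Measured in a functional assay on HCT-116 cells (Homo sapiens), read by MTT assay, with a stated time of 72 h; on this read-out lower numbers stand for stronger inhibition and higher numbers for weaker inhibition:
- compound 1 `CNc1ncnc2c1c(-c1ccco1)cn2[C@@H]1O[C@H](CO)[C@@H](O)[C@H]1O`: 230 nM
- compound 2 `CNc1ncnc2c1c(-c1ccccc1)cn2[C@@H]1O[C@H](CO)[C@@H](O)[C@H]1O`: > 20000 nM (a limit, not a number)

Compound 2 stands at the limit of > 20000 nM in this assay, at which 1 of the 2 values shown sits.

Compound 3 `CNc1ncnc2c1c(-c1cc3ccccc3o1)cn2[C@@H]1O[C@H](CO)[C@@H](O)[C@H]1O` differs from compound 2 by 1-benzofuran-2-yl in place of phenyl on an aromatic carbon.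

Within the data shown here, the one measured step bearing on this change is an at least 86-fold higher number from compound 1 to compound 2 (1.93 log units; beyond the scatter). That step is large, and its size rests on a limit. Like the furan-2-yl of compound 1, the entering 1-benzofuran-2-yl has a five-membered aromatic ring with 1 hetero atom, so a sizeable move to a lower number is expected, though probably only part of the way back.

The expected move is an at least 8.0-fold lower number from compound 2 to compound 3 (0.90 log units; beyond the scatter).

For compound 3 the estimated value is 2500 nM, with an expected range of 400 nM to 15000 nM.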

Compound 3, half-maximal inhibitory concentration: > 20000 nM
Compound 3 gave a limit, no number (the forecaster's own chance of this, stated with the estimate: 30%); middle value at least 8.0-fold (0.90 log units) away from the limit.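

In this assay, 1-benzofuran-2-yl in place of furan-2-yl gives an at least 86-fold higher number from compound 1 to compound 3 (1.93 log units; beyond the scatter). Among these compounds, a five-membered aromatic ring with 1 hetero atom on this aromatic carbon is therefore not enough to keep the value of compound 1, and with the added six-membered aromatic ring of carbon only that value is lost. The step between compound 2 and compound 3 cannot be read, as both values are limits: the limit of > 20000 nM in this assay, at which 2 of the 3 values shown sit.

Still open, from the compounds shown here alone, is whether thiophen-2-yl, or a furan-2-yl carrying a methyl group, would hold a value near that of compound 1 on this carbon. Going by these compounds, how far compound 2 and compound 3 differ also remains unknown.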